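A few compounds are considered here, and "the series" means these few. Any claim that something is new, unique, unknown or untested is made for them only; others in the source may bear on it.

Measured compounds in a functional assay for activation of Alpha-1A adrenergic receptor (Homo sapiens), read by calcium flux; on this read-out lower numbers stand for an effect already at smaller amounts and higher numbers for an effect only at larger amounts of compound:
- compound 1 `c1ccc(-c2cnccn2)c(OCC2=NCCN2)c1`: 2.51 nM
- compound 2 `c1ccc(-c2ccns2)c(OCC2=NCCN2)c1`: 5.01 nM
- compound 3 `c1ccc(-c2nccs2)c(OCC2=NCCN2)c1`: 2.51 nM

The three compounds share one core and differ only in the five-membered or six-membered heteroaryl group on an aromatic carbon. Compound 3 sits level with compound 1: no change at the digits printed from compound 1 to compound 3 (within the scatter). The other two steps are a 2.0-fold lower number from compound 2 to compound 3 (0.30 log units; within the scatter) and a 2.0-fold higher number from compound 1 to compound 2 (0.30 log units; within the scatter), and they are of the same size. Within the data shown here, all three numbers therefore lie within the scatter of one another, and no compound can be set apart as more or less active on these data.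

Compound 4 `Cn1nccc1-c1ccccc1OCC1=NCCN1` is the next member. Its change from compound 3 is 1-methyl-1H-pyrazol-5-yl in place of 1,3-thiazol-2-yl on an aromatic carbon. The measured steps that bear on it are the three heteroaryl exchanges above, each of which stayed within the scatter, so another exchange of a five-membered aromatic ring with two hetero atoms at the same carbon is expected to give no step beyond the scatter in this assay, with at most a slight drift toward a higher number.

Compound 4 is expected at 4 nM, with a range from 1.5 nM to 12 nM. The expected step is a 1.6-fold higher number from compound 3 to compound 4 (0.20 log units; within the scatter).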

Compound 4, half-maximal effective concentration: 39.8 nM
For compound 4 the middle estimate is 10-fold (1.00 log units) below the measured one, outside the stated range (above it).
By their numbers in this assay, from the lowest: compounds 1, 3 and 2 (each within the scatter of the next); then compound 4.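

In this assay the position on an aromatic carbon, ortho to a group of 7 heavy atoms, is not indifferent to the heteroaryl group it carries: 1-methyl-1H-pyrazol-5-yl gives a 16-fold higher number from compound 3 to compound 4 (1.20 log units; beyond the scatter) when it replaces 1,3-thiazol-2-yl, a 7.9-fold higher number from compound 2 to compound 4 (0.90 log units; beyond the scatter) when it replaces 1,2-thiazol-5-yl and a 16-fold higher number from compound 1 to compound 4 (1.20 log units; beyond the scatter) when it replaces pyrazin-2-yl. All three steps lie beyond the scatter while the exchanges among compounds 1, 2 and 3 stayed within it, so compound 4 stands apart from that group, and sharing one five-membered aromatic ring with 2 hetero atoms and the same donor and acceptor counts did not keep compound 3 and compound 4 level. The two groups still differ in heavy atom count and in their atoms, and nothing available ties the step to either difference or to any other cause.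

Open, as far as these compounds go, is whether the step follows the methyl group on the ring nitrogen or the pyrazole ring itself, which an unsubstituted pyrazole or an N-ethyl pyrazole at the same carbon would separate. Also open, from the compounds shown here alone, is how far this position tolerates groups of another kind, such as a plain phenyl ring or a primary amine.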